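The compounds below may be only part of what the source reports. "The series", "measured", "known", "first", "only" and "open" are said of these compounds alone.

Compound 1 `CC(=O)C1=C(C)NC(=O)NC1c1ccsc1` gives 1% in an assay on membranes from HeLa cells for displacement of a labelled ligand from adenosine receptor A3 (Homo sapiens), read by scintillation counting, with a stated time of 180 min, tested at 1 uM; on this read-out higher numbers stand for more inhibition at the one concentration tested (going by the name of the read-out) and lower numbers for less inhibition.
Compound 2 `CCSC(=O)C1=C(C)NC(=O)NC1c1ccsc1` gives 2% in this assay.
Compound 3 `CCC(CC)OC(=O)C1=C(C)NC(=O)NC1c1ccsc1` gives 6% in this assay.

Compound 3 holds the highest of the three numbers, yet both steps into it stay within the scatter: a number 5 percentage points higher from compound 1 to compound 3 (within the scatter) and a number 4 percentage points higher from compound 2 to compound 3 (within the scatter). Compound 4 `CC1=C(C(=O)OC2CCCCC2)C(c2ccsc2)NC(=O)N1` differs from compound 3 by cyclohexyl in place of pentan-3-yl on an oxygen next to a carbonyl group. The steps measured so far all exchange the group attached to the carbonyl carbon, and none of them moves beyond the scatter, including a number 1 percentage points higher from compound 1 to compound 2 (within the scatter). The change to compound 4 is of the same kind, a swap of the group on the oxygen, so no step beyond the scatter is expected in this assay. Compound 4 is therefore expected at 6%, within 0% to 16%. The expected step is no change at the digits printed from compound 3 to compound 4 (within the scatter).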

Compound 4, a percentage reported as inhibition, at one concentration (the size of the read-out at that concentration, not a potency): 1%
Estimate against measurement, compound 4: 5 percentage points above, and the stated range covers the measured number.
By their numbers in this assay, from the lowest: compounds 1, 4, 2 and 3 (each within the scatter of the next).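

In this assay a ring on the oxygen next to a carbonyl group, cyclohexyl in place of pentan-3-yl, gives a number 5 percentage points lower from compound 3 to compound 4 (within the scatter) and so does not separate from the open chain. Cyclohexyloxy on the carbonyl carbon reads the same way, with a number 1 percentage points lower from compound 2 to compound 4 (within the scatter) against ethylsulfanyl and no change at the digits printed from compound 1 to compound 4 (within the scatter) against methyl, so ring, chains and methyl are not told apart at this position. No supporting data bear on why these numbers stay so close.

Open, from the compounds shown here alone, is whether an amine or a carboxylic acid on the carbonyl carbon, or a longer chain on the oxygen, would give a step beyond the scatter. Also open, going by these compounds, is whether any change elsewhere on the shared core would do so.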